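This account rests on a few compounds, and the source may have more. Where it says the series, first, only, none or still open, it means among the compounds named here.

Measured compounds: compound 1 `CCC1C(=O)N(CCCCCCOc2ccc(Cl)cc2)/C(=N\C#N)N1c1ccncc1`, 406 nM; compound 2 `CCC1C(=O)N(CCCCCCCOc2ccc(Cl)cc2)/C(=N\C#N)N1c1ccncc1`, 1280 nM; compound 3 `N#C/N=C1\N(CCCCCCOc2ccc(Cl)cc2)C(=O)C(c2ccccc2)N1c1ccncc1`, 3340 nM.

All three were tested in a functional assay on NUGC cells (stomach, Homo sapiens) for cytotoxicity; on this read-out higher numbers stand for weaker inhibition and lower numbers for stronger inhibition. Compound 1 gives 406 nM in this assay and is the lowest number of the three. The change (4-chlorophenoxy)methyl in place of 4-chlorophenoxy on a saturated chain carbon, six bonds along the chain from an amide-type nitrogen in a ring produced a 3.2-fold higher number from compound 1 to compound 2 (0.50 log units; beyond the scatter). The cores of compound 1 and compound 3 differ by phenyl in place of ethyl on a saturated ring carbon, which produced an 8.2-fold higher number from compound 1 to compound 3 (0.92 log units; beyond the scatter), leaving compound 3 with the highest number of the three.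

Compound 4 `N#C/N=C1\N(CCCCCCCOc2ccc(Cl)cc2)C(=O)C(c2ccccc2)N1c1ccncc1` is not yet measured. It differs from compound 3 by (4-chlorophenoxy)methyl in place of 4-chlorophenoxy on a saturated chain carbon, six bonds along the chain from an amide-type nitrogen in a ring, the same change that took compound 1 to compound 2; the change appears twice among these compounds. Because the earlier step was a 3.2-fold higher number from compound 1 to compound 2 (0.50 log units; beyond the scatter), compound 4 is expected to show a step of similar size, a 2.4-fold higher number from compound 3 to compound 4 (0.38 log units; beyond the scatter), in this assay. Compound 4 is therefore estimated at 8000 nM, with a range from 3500 nM to 20000 nM.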

Compound 4, half-maximal inhibitory concentration: 3350 nM
Estimate against measurement, compound 4: 2.4-fold (0.38 log units) above; the measured number lies below the stated range.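

In this assay, (4-chlorophenoxy)methyl in place of 4-chlorophenoxy gave a 1.0-fold higher number from compound 3 to compound 4 (0.00 log units; within the scatter), so the step seen on the core of compound 1 did not carry over to the core of compound 3: the same change on two cores in this assay, a 3.2-fold higher number (0.50 log units; beyond the scatter) from compound 1 to compound 2 and a 1.0-fold higher number (0.00 log units; within the scatter) from compound 3 to compound 4, 3.1-fold (0.50 log units) apart, beyond the scatter of two such steps

Phenyl in place of ethyl on a saturated ring carbon, read on the longer chain, gave a 2.6-fold higher number from compound 2 to compound 4 (0.42 log units; beyond the scatter), which keeps the direction of the earlier step but not its size: the same change on two cores in this assay, an 8.2-fold higher number (0.92 log units; beyond the scatter) from compound 1 to compound 3 and a 2.6-fold higher number (0.42 log units; beyond the scatter) from compound 2 to compound 4, 3.1-fold (0.50 log units) apart, beyond the scatter of two such steps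

Both comparisons rest on the same four compounds, so they show one dependence between the two changes, and they do not show why it arises or whether it extends to other cores.

The compounds shown leave open how a methyl or benzyl group on that saturated ring carbon would alter the chain step. They also leave open how a shorter or a longer chain would read on either core.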